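A few compounds are considered here, and "the series" means these few. Any claim that something is new, unique, unknown or untested is made for them only; others in the source may bear on it.

Compound 3 `COc1ccc(C(=O)Nc2c(Br)cncc2Br)cc1OC1CCCC1` — 7 nM
Compound 1 `COc1ccc(C(=O)Nc2ccccc2C)cc1OC1CCCC1` — 300 nM
Compound 2 `COc1ccc(C(=O)Nc2ccncc2)cc1OC1CCCC1` — 800 nM

In an assay on isolated protein for inhibition of phosphodiesterase 4A (Sus scrofa) (a higher number here means a weaker inhibitor, a lower number a stronger inhibitor), compound 3 gives 7 nM, the lowest of the three numbers; compound 1 gives 300 nM and compound 2 gives 800 nM. Both steps toward compound 3 are large: a 43-fold lower number from compound 1 to compound 3 (1.63 log units; beyond the scatter) and a 110-fold lower number from compound 2 to compound 3 (2.06 log units; beyond the scatter), whereas the step between the two weaker compounds is modest, a 2.7-fold higher number from compound 1 to compound 2 (0.43 log units; beyond the scatter).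

Compound 4 `COc1ccc(C(=O)Nc2c(C)nsc2C)cc1OC1CCCC1` changes the amide substituent of compound 3: 3,5-dimethyl-1,2-thiazol-4-yl in place of 3,5-dibromopyridin-4-yl on an amide-type nitrogen. The two bromines that set compound 3 apart from compound 1 and compound 2 are gone; in their place stand two methyl groups on a five-membered ring with two hetero atoms. Among the measured compounds shown here, none of the measured steps covers this exact exchange. The nearest guidance is the pair of large steps from compound 1 and compound 2 to compound 3, which show how much the number depends on what flanks the amide nitrogen, and compound 1, whose single methyl on that ring gives 300 nM.

Compound 4 is therefore expected to give a higher number than compound 3 in this assay, a step of about a 14-fold higher number from compound 3 to compound 4 (1.15 log units; beyond the scatter), but to stay at or below the level of compound 1. The estimate for compound 4 is 100 nM, with a range from 20 nM to 600 nM.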

Compound 4, half-maximal inhibitory concentration: 500 nM
Beside the measured number, compound 4's estimate is 5.0-fold (0.70 log units) below it; the range from low to high includes it.
By their numbers in this assay, from the lowest: compound 3; then compounds 1, 4 and 2 (each within the scatter of the next, the first and the last beyond it).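

On the amide-type nitrogen, the 3,5-dimethyl-1,2-thiazol-4-yl group does not keep the low number that the 3,5-dibromopyridin-4-yl group gives in this assay and the exchange is a large one, a 71-fold higher number from compound 3 to compound 4 (1.85 log units; beyond the scatter). Compound 4 instead falls in with the two weaker compounds, with a 1.6-fold lower number from compound 2 to compound 4 (0.20 log units; within the scatter) and a 1.7-fold higher number from compound 1 to compound 4 (0.22 log units; within the scatter) and so among these four only compound 3 stands apart, which shows that two substituents on the ring attached to this nitrogen do not by themselves bring the number down to the level of compound 3. Nothing in the data shown accounts for this large step.

The exchange replaces the ring and its two substituents at once, so the compounds shown leave open whether the low number of compound 3 goes with the bromines, with the six-membered ring or only with the two together. A 3,5-dimethylpyridin-4-yl group or a 3,5-dibromo-1,2-thiazol-4-yl group on the same amide-type nitrogen would change one of these without the other and so separate them.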